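Shifting the Trifluoromethyl Group on Compound 2's Chlorophenyl Ring

A few compounds are considered here, and "the series" means these few. Any claim that something is new, unique, unknown or untested is made for them only; others in the source may bear on it.

Measured compounds:
Compound 1, `CC/C(=C(/c1ccc(/C=C/C(=O)O)cc1)c1cc2ccccc2[nH]1)c1ccccc1C(F)(F)F`: 8 nM
Compound 2, `CC/C(=C(/c1ccc(/C=C/C(=O)O)cc1)c1cc2ccccc2[nH]1)c1ccc(Cl)cc1C(F)(F)F`: 4 nM

For the measured compounds named here, in a functional assay on MCF7 cells (Homo sapiens) for inhibition (a lower number here means a stronger inhibitor, a higher number a weaker inhibitor), compound 2 gives 4 nM, the lowest of the two numbers so far. Going by the values given here, its only neighbour is compound 1, and the single measured step, a 2.0-fold lower number from compound 1 to compound 2 (0.30 log units; within the scatter), lies within the scatter, so the two compounds cannot be told apart on potency.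

Compound 3, `CC/C(=C(/c1ccc(/C=C/C(=O)O)cc1)c1cc2ccccc2[nH]1)c1ccc(Cl)c(C(F)(F)F)c1`, has not yet been measured. It differs from compound 2 by 4-chloro-3-(trifluoromethyl)phenyl in place of 4-chloro-2-(trifluoromethyl)phenyl on a double-bonded chain carbon bound to a double-bonded chain carbon and a saturated chain carbon. The same atoms are present; only the carbon of the ring that carries the trifluoromethyl group changes. Among the compounds with values here, no measured step bears on such a rearrangement: the one step known concerns chlorine in place of hydrogen, a different kind of change, and it says nothing about moving a group around the ring. With no guidance either way, the number for compound 3 is expected to stay close to that of compound 2, with a wider margin of uncertainty than usual.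

Compound 3 is therefore estimated at 8 nM, within a range of 2 nM to 40 nM. This corresponds to an expected step of a 2.0-fold higher number from compound 2 to compound 3 (0.30 log units; within the scatter).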

Compound 3, half-maximal inhibitory concentration: 2200 nM
The estimate for compound 3 lay 280-fold (2.44 log units) below the measured number; measured number outside the range, above it.
By their numbers in this assay, from the lowest: compounds 2 and 1 (each within the scatter of the next); then compound 3.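

In this assay, the earlier pair showed only that adding a chlorine made no clear difference, whereas this result shows that the carbon carrying the trifluoromethyl group matters a great deal: with the same atoms and the same counts of hydrogen-bond donors and acceptors, replacing 4-chloro-2-(trifluoromethyl)phenyl with 4-chloro-3-(trifluoromethyl)phenyl gives a 550-fold higher number from compound 2 to compound 3 (2.74 log units; beyond the scatter). Compound 3 is also much weaker than the chlorine-free compound 1, with a 280-fold higher number from compound 1 to compound 3 (2.44 log units; beyond the scatter), so the loss is not limited to the comparison with compound 2. Nothing available explains why rearranging the same atoms on this ring has so large an effect.

The compounds shown leave open whether the loss is specific to the trifluoromethyl group or would also occur with another group on the same ring carbon, such as a methyl or a nitrile. They also leave open whether the chlorine plays any part in the loss, a question that compound 3 alone cannot settle.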